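The source may hold more compounds than are shown below. What is called first, only, known or untested is meant among the compounds shown, and "the series" means these compounds.

Three compounds sharing one core were tested in an ADME assay on Vero cells (Chlorocebus sabaeus) for inhibition, read by sulforhodamine B assay, with a stated time of 48 h; on this read-out higher numbers stand for weaker inhibition of growth and lower numbers for stronger inhibition of growth. Compound 1 `CC1=CC[C@H](C(C)(C)NC(=S)N/N=C/c2ccccc2Cl)CC1` gives only a limit, > 100000 nM. Compound 2 `CC1=CC[C@H](C(C)(C)NC(=S)N/N=C/c2cccc(Cl)c2)CC1` also gives only a limit, > 100000 nM. Compound 3 `CC1=CC[C@H](C(C)(C)NC(=S)N/N=C/c2ccccc2[N+](=O)[O-])CC1` again gives only a limit, > 100000 nM. The cores of compound 1 and compound 2 differ as 3-chlorophenyl in place of 2-chlorophenyl on a carbon with a double bond to nitrogen, and the step that the two limits leave unreadable from compound 1 to compound 2 cannot be read. Compound 3 arises from compound 1 by nitro in place of chloro on an aromatic carbon; that step, a step that the two limits leave unreadable from compound 1 to compound 3, is likewise unreadable because every value sits at the limit of > 100000 nM in this assay, at which 3 of the 3 values shown sit. Compound 4 `CC1=CC[C@H](C(C)(C)NC(=S)N/N=C/c2cccc([N+](=O)[O-])c2)CC1` is not yet measured. It comes from compound 2 by nitro in place of chloro on an aromatic carbon, the same kind of change, though here the group stands meta to a large group rather than ortho to a large group. The step from compound 2 to compound 4 is expected to be a step that the limit leaves unreadable from compound 2 to compound 4. This rests on compound 3 giving > 100000 nM after the same kind of change. Compound 4 is therefore expected to give 150000 nM, between 60000 nM and 400000 nM, most likely again as a limit.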

Compound 4, concentration for total growth inhibition: > 100000 nM
Compound 4: only a limit was reported; the forecaster's own chance of this, stated with the estimate: 85%; the middle value does not contradict the limit.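

No step can be read between compound 2 and compound 4, because both values are limits, not numbers: the limit of > 100000 nM in this assay, at which 4 of the 4 values shown sit.

The compounds shown leave open how strongly any of them inhibits growth in this assay, and whether nitro in place of chloro changes that.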